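This account rests on a few compounds, and the source may have more. Where it says the series, first, only, none or still open, it means among the compounds named here.

Working notes on the series.

Within the data shown here, compound 1 `COc1ccc(NC2=CC(=O)c3c(nc4n3[C@H]3OC[C@@H](O)[C@H]3OC4)C2=O)cc1` is the only member for which a functional assay on MCF7 cells (Homo sapiens) for inhibition, read by sulforhodamine B assay (on this read-out higher numbers stand for weaker inhibition and lower numbers for stronger inhibition), returns a number rather than a limit; in this assay compound 1 gives 4470 nM. Compound 2 `COc1cccc(NC2=CC(=O)c3nc4n(c3C2=O)[C@H]2OC[C@@H](O)[C@H]2OC4)c1` reaches only a limit in this assay, compound 2 giving > 4000 nM. Compound 3 `O=C1C=C(N2CCCCC2)C(=O)c2c1nc1n2[C@H]2OC[C@@H](O)[C@H]2OC1` likewise stops at a limit in this assay, compound 3 giving > 8000 nM. Among the measured compounds shown here, the one single-point change that has been measured, a step that the two limits leave unreadable from compound 2 to compound 3, cannot be sized. Compound 2 rests at the limit of > 4000 nM in this assay, at which 1 of the 3 values shown sits. Compound 3 rests at the limit of > 8000 nM in this assay, at which 1 of the 3 values shown sits.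

Compound 4 `O=C1C(NCc2ccccc2)=CC(=O)c2c1nc1n2[C@H]2OC[C@@H](O)[C@H]2OC1` has not yet been measured. It differs from compound 1 in one place: benzyl in place of 4-methoxyphenyl on an amine nitrogen. For the measured compounds named here, no measured step touches the substituent on this amine nitrogen with a readable size, so none of the recorded steps bears on the change; what can be expected for compound 4 rests on compound 1 alone, which sits at the weak end of what this assay reports as a number. Nothing in the shown data points to a gain in potency for benzylamino over (4-methoxyphenyl)amino, and the expected step of a 1.3-fold higher number from compound 1 to compound 4 (0.13 log units; within the scatter) is therefore taken to lie within the scatter, with a wide margin either way. Compound 4 is expected to give 6000 nM in this assay, between 2000 nM and 20000 nM.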

Compound 4, half-maximal inhibitory concentration: > 8000 nM
Compound 4 ended at the assay's limit; the forecaster's own chance of this, stated with the estimate: 40%; at least 1.3-fold (0.12 log units) between middle value and limit.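

In this assay, among these compounds, replacing the aryl group on this amine nitrogen gives an at least 1.7-fold higher number from compound 1 to compound 4 (0.25 log units; that floor lies within the scatter), the first step at this substituent with a readable floor. The floor does not by itself separate the pair beyond the scatter, and the true size of the step may be larger, but the result offers no sign of a gain for benzylamino over (4-methoxyphenyl)amino. Among the compounds shown, compound 1 remains the only one to return a number rather than a limit, and the results now gather at the upper limit of the read-out: the limit of > 8000 nM in this assay, at which 2 of the 4 values shown sit.

The compounds shown leave open how far compound 4 really lies from compound 1, and whether the methoxy group of compound 1 has any bearing on its value. A plain phenylamino group, or a 2-phenylethylamino group with its longer chain, on this same nitrogen would test these two points against the shared core.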